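Carbamate nitrogen substituent change in ceramide-like series

The source may hold more compounds than are shown below. What is called first, only, known or untested is meant among the compounds shown, and "the series" means these compounds.

Measured compounds:
compound 1 `CCCCCCCCCCCCC/C=C/[C@@H](O)[C@H](COC(=O)NCCCN(C)C)NC(=O)C(C)(C)C` — 4900 nM
compound 2 `CCCCCCCCCCCCC/C=C/[C@@H](O)[C@H](COC(=O)NCCC(C)(C)C)NC(=O)C(C)(C)C` — 77000 nM

In an assay on membranes from brain for inhibition of sphingomyelin phosphodiesterase 2 (Rattus norvegicus), using microsomes (a higher number here means a weaker inhibitor, a lower number a stronger inhibitor), compound 2 gives the higher of the two numbers; compound 1 gives a lower number, the step of a 16-fold higher number from compound 1 to compound 2 (1.20 log units; beyond the scatter). Compound 3 `CCCCCCCCCCCCC/C=C/[C@@H](O)[C@H](COC(=O)Nc1ccccn1)NC(=O)C(C)(C)C` differs from compound 2 by pyridin-2-yl in place of 3,3-dimethylbutyl on an amide-type nitrogen. For the measured compounds named here, no measured step covers an aromatic group on this nitrogen; the only step, a 16-fold higher number from compound 1 to compound 2 (1.20 log units; beyond the scatter), shows a large move when the nitrogen-bearing chain end was swapped for tert-butyl. Compound 3 brings a ring nitrogen acceptor back in, so a move back toward lower numbers is expected, with wide uncertainty. Compound 3 is expected at 20000 nM (range 5000 nM to 80000 nM), an estimated 3.9-fold lower number from compound 2 to compound 3 (0.59 log units; beyond the scatter).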

Compound 3, half-maximal inhibitory concentration: 7900 nM
Compound 3: middle estimate off by 2.5-fold (0.40 log units), on the high side; measured number inside the range.
By their numbers in this assay, from the lowest: compounds 1 and 3 (each within the scatter of the next); then compound 2.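

In this assay, an aromatic ring on the amide-type nitrogen holds up: pyridin-2-yl in place of 3,3-dimethylbutyl gives a 9.7-fold lower number from compound 2 to compound 3 (0.99 log units; beyond the scatter), while pyridin-2-yl in place of 3-(dimethylamino)propyl gives a 1.6-fold higher number from compound 1 to compound 3 (0.21 log units; within the scatter). Two quite different nitrogen-bearing groups thus sit within the scatter of each other, and the nitrogen-free 3,3-dimethylbutyl of compound 2 stands apart from both. No available evidence accounts for this.

Open, on these data alone, is whether the ring nitrogen matters at all, which phenyl in place of pyridin-2-yl would test. Also open, as far as these compounds go, is how pyridin-3-yl or pyridin-4-yl would compare on this nitrogen.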